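The source may hold more compounds than are shown below. What is called first, only, known or untested is meant among the compounds shown, and "the series" means these compounds.

Compound 1 `CC(=O)c1ccc(OCc2ccccc2F)cc1` is the reference point of this small set. In an assay on isolated protein for inhibition of Amine oxidase [flavin-containing] B (Homo sapiens), read by Amplex Red, with a stated time of 15 min (a lower number here means a stronger inhibitor, a higher number a weaker inhibitor), compound 1 gives 56.9 nM. Compound 2 `CC(=O)c1ccc(OCc2ccccc2Cl)cc1` keeps the same core and carries chloro in place of fluoro on an aromatic carbon; in this assay compound 2 gives 311 nM, so the step is a 5.5-fold higher number from compound 1 to compound 2 (0.74 log units; beyond the scatter). Compound 3 `CC(=O)c1cccc(OCc2cccc(F)c2)c1` rests on a different core, and how the two cores differ is not broken down here. In this assay compound 3 gives 193 nM, a higher number than that of compound 1, while its number and that of compound 2 lie within the scatter of each other. Compound 4 `CC(=O)c1cccc(OCc2cccc(Cl)c2)c1` is not yet measured. It carries chloro in place of fluoro on an aromatic carbon, the same kind of change as from compound 1 to compound 2, but the place differs: in compound 4 the new group sits meta to a large group, whereas in compound 2 it sat ortho to a large group. For compound 4 a step of a 3.1-fold higher number from compound 3 to compound 4 (0.49 log units; beyond the scatter) is expected, somewhat smaller than the earlier one because a 5.5-fold higher number from compound 1 to compound 2 (0.74 log units; beyond the scatter) was seen at another place. Compound 4 is therefore estimated at 600 nM, with a likely range from 250 nM to 1500 nM.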

Compound 4, half-maximal inhibitory concentration: 34.2 nM
Estimate against measurement, compound 4: 18-fold (1.24 log units) above; measured number below the stated range.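

In this assay, chloro in place of fluoro on an aromatic carbon, here meta to a large group, gives a 5.6-fold lower number from compound 3 to compound 4 (0.75 log units; beyond the scatter), and set beside the same exchange on the core of compound 1, the direction is reversed: the same change on two cores in this assay, a 5.5-fold higher number (0.74 log units; beyond the scatter) from compound 1 to compound 2 and a 5.6-fold lower number (0.75 log units; beyond the scatter) from compound 3 to compound 4, 31-fold (1.49 log units) apart, beyond the scatter of two such steps The change therefore does not carry from one core to the other in this series, and a result on one core gave no safe guide to the direction on the other. What the two pairs do not show is whether the core or the place of the halogen decides the direction, since both differ between them, and two pairs establish no rule for other cores.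

The compounds shown leave open how a bromo, methyl or methoxy group would behave in the place of the halogen on either core. They also leave open whether an amide or a carboxylic acid in place of the ketone would keep the same reversal.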